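Swapping 1-phenylethyl for 2-hydroxyethyl at an assay limit

The compounds below may be only part of what the source reports. "The series", "measured", "known", "first", "only" and "open" are said of these compounds alone.

Compounds measured in a functional assay on MDA-MB-435 cells (Homo sapiens) for cytotoxicity, read by MTT assay, with a stated time of 72 h; on this read-out lower numbers stand for stronger inhibition and higher numbers for weaker inhibition:
Compound 1 `O=C(NCc1ccc(F)cc1)c1nc(NCCO)c2cccnc2c1O`: > 20000 nM (a limit)
Compound 2 `C[C@@H](Nc1c(C(=O)NCc2ccc(F)cc2)nc(Br)c2cccnc12)c1ccccc1`: > 20000 nM (a limit)
Compound 3 `N[C@H]1CC[C@H](Nc2c(C(=O)NCc3ccc(F)cc3)nc(N3CCCCC3)c3cccnc23)CC1`: 5000 nM

Compound 2 has no numerical value in this assay. Its result is only the limit > 20000 nM. The same limit applies to compound 1, and the overall position is the limit of > 20000 nM in this assay, at which 2 of the 3 values shown sit. Only compound 3 gives an actual number, 5000 nM.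

Compound 4 `O=C(NCc1ccc(F)cc1)c1nc(Br)c2cccnc2c1NCCO` has not yet been measured. It differs from compound 2 in one place, with 2-hydroxyethyl in place of 1-phenylethyl on a nitrogen on an aromatic ring. Among the measured compounds shown here, no measured pair of compounds isolates this change, so the data give no direct guide to its size. Compound 1 also carries a 2-hydroxyethyl group on a nitrogen, and its result is the limit > 20000 nM. On that basis, no shift beyond the usual scatter is expected in either direction in this assay, and another result reported only as a limit is the likeliest outcome. The estimated step is a number no higher from compound 2 to compound 4 (the limit leaves the size open). For compound 4 the estimated value is 20000 nM, with an expected range from 8000 nM to 40000 nM.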

Compound 4, half-maximal inhibitory concentration: > 20000 nM
Compound 4 ended at the assay's limit (the forecaster's own chance of this, stated with the estimate: 70%); the middle value sits exactly at the limit.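

In this assay compound 2 and compound 4 both stand only as limits, so no step can be read between them. The compounds shown leave open whether 2-hydroxyethyl in place of 1-phenylethyl on this nitrogen changes the result at all, and by how much, since neither compound has an actual number.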